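The compounds below may be only part of what the source reports. "The series", "measured", "known", "first", "only" and "open" are said of these compounds alone.

The measured compounds:
compound 1 `COc1ccc(/C(=N/O)c2cccc3ccccc23)c(OC)c1OC` — in a functional assay on MDA-MB-231 cells (Homo sapiens) for inhibition, read by sulforhodamine B assay, with a stated time of 48 h (a higher number here means a weaker inhibitor, a lower number a stronger inhibitor), compound 1 gives 2500 nM
compound 2 `C=CCC(O)(c1ccc(OC)c(OC)c1OC)c1cccc2ccccc12` — in this assay compound 2 gives > 20000 nM, which is a limit of the assay
compound 3 `COc1ccc(C(O)(Cc2ccc(F)cc2)c2cccc3ccccc23)c(OC)c1OC` — in this assay compound 3 gives 5440 nM

Compound 1 holds the lowest of the two numbers shown in this assay. Compound 3 stands nearest to it, with a number higher by a gap that lies beyond the scatter. The value for compound 2 is a limit and not a number (the limit of > 20000 nM in this assay, at which 1 of the 3 values shown sits). Within the data shown here, the only step between two measured compounds that differ in one place is an at least 3.6-fold lower number from compound 2 to compound 3 (0.56 log units; beyond the scatter); it concerns a saturated chain carbon and not the oxygen at which compound 4 departs from compound 1, so it offers no direct guide.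

Compound 4 `CCOC(=O)/C=C/CO/N=C(/c1ccc(OC)c(OC)c1OC)c1cccc2ccccc12` differs from compound 1 in this way: 3-(ethoxycarbonyl)prop-2-en-1-yl in place of hydrogen on an oxygen. Among the measured compounds shown here, no measured step bears on this change, so the expectation rests on compound 1 alone and carries wide uncertainty. The estimated step is a 1.2-fold higher number from compound 1 to compound 4 (0.08 log units; within the scatter), expected to fall within or close to the usual scatter rather than in either direction. Compound 4 is therefore estimated at 3000 nM, with a range from 800 nM to 12000 nM.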

Compound 4, half-maximal inhibitory concentration: > 20000 nM
Compound 4: a limit, no number; the forecaster's own chance of this, stated with the estimate: 10%; middle value at least 6.6-fold (0.82 log units) away from the limit.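

Placing 3-(ethoxycarbonyl)prop-2-en-1-yl in place of hydrogen on the oxygen whose other neighbour is the double-bonded nitrogen gives an at least 8.0-fold higher number from compound 1 to compound 4 (0.90 log units; beyond the scatter), the first measured step at this oxygen. In this assay compound 4 gives > 20000 nM, which is a limit of the assay and not a number. The oxygen of compound 1 is thus not indifferent to what it carries, at least for this change from hydroxy to (3-(ethoxycarbonyl)prop-2-en-1-yl)oxy, but the full size of the step cannot be read, and compound 4 now shares its limit with compound 2: the limit of > 20000 nM in this assay, at which 2 of the 4 values shown sit.

This single step does not separate the part played by the ethyl ester, the double bond or the length of the chain from the part played by replacing the hydrogen itself. From the compounds shown here alone, how a plain methyl or ethyl on this oxygen would read, or a chain of the same length ending in a carboxylic acid or an amine, remains open.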